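Methoxyphenyl for dimethylphenyl on the amine of compound 2

The source may report more compounds than this note shows. Statements on the series, on what has been measured and on what is new or still open speak of the compounds shown alone.

Measured so far in a functional assay on MCF7 cells (Homo sapiens) for inhibition, read by sulforhodamine B assay; a lower number here means a stronger inhibitor, a higher number a weaker inhibitor:
- compound 1, `Cc1ccc(NC2=CC(=O)c3nc4n(c3C2=O)[C@H]2OC[C@@H](O)[C@H]2OC4)cc1C`: 2080 nM
- compound 2, `Cc1ccc(NC2=CC(=O)c3c(nc4n3[C@H]3OC[C@@H](O)[C@H]3OC4)C2=O)cc1C`: 4950 nM
- compound 3, `COc1cccc(NC2=CC(=O)c3nc4n(c3C2=O)[C@H]2OC[C@@H](O)[C@H]2OC4)c1`: in this assay compound 3 reaches only a limit, > 4000 nM, and not a number.

Among the two numbers shown, compound 2 stands highest; its nearest neighbour, compound 1, lies a step below it that is beyond the scatter. The third value is a limit (the limit of > 4000 nM in this assay, at which 1 of the 3 values shown sits).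

Compound 4, `COc1ccccc1NC1=CC(=O)c2c(nc3n2[C@H]2OC[C@@H](O)[C@H]2OC3)C1=O`, has not yet been measured in this assay. It differs from compound 2 in one place: 2-methoxyphenyl in place of 3,4-dimethylphenyl on an amine nitrogen.

For the measured compounds named here, only one measured step resembles this change. It is an at least 1.9-fold higher number from compound 1 to compound 3 (0.28 log units; that floor lies within the scatter), which also trades the 3,4-dimethylphenyl group for a methoxyphenyl group on the amine nitrogen, though there the methoxy sits differently on the ring and the shared core is attached the other way round. Going by these compounds, that step ran to a weaker number and stopped at a limit, so its full size is unknown. Starting from compound 2, which already gives the weaker of the two numbers, a step of similar direction is expected for compound 4, a 1.8-fold higher number from compound 2 to compound 4 (0.26 log units; within the scatter), with a fair chance that this assay again reports only a limit. Compound 4 is estimated at 9000 nM, in the range 3500 nM to 25000 nM.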

Compound 4, half-maximal inhibitory concentration: 6580 nM
For compound 4 the middle estimate is 1.4-fold (0.14 log units) above the measured one; measured number inside the range.
By their numbers in this assay, from the lowest: compound 1; then compounds 2 and 4 (each within the scatter of the next).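

Exchanging 3,4-dimethylphenyl for 2-methoxyphenyl on this amine nitrogen, read in this assay, gives a 1.3-fold higher number from compound 2 to compound 4 (0.12 log units; within the scatter), so on the core of compound 2 the measurement cannot separate the two groups. The earlier step could not settle this, as compound 3 reached only a limit, which gave that step a floor and no full size: the limit of > 4000 nM in this assay, at which 1 of the 4 values shown sits. Here both partners carry real numbers, so a dimethylphenyl-to-methoxyphenyl exchange on an amine nitrogen has a measured size, and on this core that size is small enough to be lost in the ordinary spread of repeated measurements.

Whether the exchange stays this small on the core of compound 1 remains open, and so does the effect of moving the methoxy group around the ring on a single core, as no pair shown varies only that. Also open, going by these compounds, is what a pyridine ring, a cyclohexyl group or a longer alkyl chain on this amine nitrogen would give in this assay.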